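A few compounds are considered here, and "the series" means these few. Any claim that something is new, unique, unknown or untested is made for them only; others in the source may bear on it.

Compound 1 `COCCC(=O)NCCCNc1nc(Nc2cccc(F)c2)ncc1Br`: 60 nM
Compound 2 `Cc1nn(C)c2cc(Nc3ncc(C4CC4)c(NCCCNC(=O)C4CCC4)n3)ccc12`: 7 nM

In an assay on isolated protein for inhibition of serine/threonine-protein kinase TBK1 (Homo sapiens) (a higher number here means a weaker inhibitor, a lower number a stronger inhibitor), compound 1 stands at the highest of the two numbers; compound 2 gives a lower number, and that gap lies beyond the scatter. Compound 3 `O=C(NCCCNc1nc(Nc2cccc(F)c2)ncc1Br)C1CCC1` differs from compound 1 in one place: cyclobutyl in place of 2-methoxyethyl on a carbonyl carbon. Among the compounds with values here, no pair of measured compounds shows this change on its own; compound 2 also carries a cyclobutylcarbonyl group but differs from compound 1 elsewhere as well. I expect a modest move toward a lower number, a 1.5-fold lower number from compound 1 to compound 3 (0.18 log units; within the scatter), not clearly beyond the scatter. For compound 3 I estimate 40 nM, with a range from 15 nM to 120 nM.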

Compound 3, half-maximal inhibitory concentration: 2 nM
Compound 3: the middle estimate sits 20-fold (1.30 log units) above what was measured; measured number below the stated range.
By their numbers in this assay, from the lowest: compound 3; then compound 2; then compound 1.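

In this assay, the group on the carbonyl carbon turns out to matter a great deal: cyclobutyl in place of 2-methoxyethyl gives a 30-fold lower number from compound 1 to compound 3 (1.48 log units; beyond the scatter), although both groups have 4 heavy atoms. Cyclobutyl has no hydrogen-bond acceptor and 2-methoxyethyl has one, but a single pair cannot show which part of the swap counts. Nothing at hand explains the step. Open, from the compounds shown here alone, is how cyclopropyl, cyclopentyl or a phenyl ring would behave on this carbonyl carbon. Also open, going by these compounds, is whether an open-chain group without oxygen, such as isobutyl, would match cyclobutyl.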